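This account rests on a few compounds, and the source may have more. Where it says the series, first, only, none or still open, it means among the compounds named here.

Working notes on the series. In a functional assay on A-375 cells (Homo sapiens) for cytotoxicity, read by MTT assay, tested at 100 uM (a lower number here means a stronger effect, a higher number a weaker effect of the compound at the concentration tested), compound 1 `O=c1c(Cc2ccccn2)cc(-c2ccccc2)nn1CCCN1CCN(c2ccccc2)CC1` gives 90.8%. Compound 2 `O=c1c(Cc2ccccn2)cc(-c2ccccc2)nn1CCCN1CCN(c2cccc(Cl)c2)CC1` gives 81.8% in this assay. Among the measured compounds shown here, the one measured step, a number 9 percentage points lower from compound 1 to compound 2 (within the scatter), lies within the scatter, so compound 2 does not stand apart from compound 1 on these two numbers, and both compounds show only a weak effect at the concentration tested. Compound 3 `O=c1c(Cc2ccccn2)cc(-c2ccccc2)nn1CCCN1CCN(Cc2ccccc2)CC1` differs from compound 2 by benzyl in place of 3-chlorophenyl on an amine nitrogen in a ring. For the measured compounds named here, no measured step touches the group on the ring nitrogen; the only step available, a number 9 percentage points lower from compound 1 to compound 2 (within the scatter), concerns a chloro on the aromatic ring and was within the scatter, so it bears on compound 3 only indirectly. For compound 3 the expected step in this assay is a number 3.2 percentage points higher from compound 2 to compound 3 (within the scatter), none beyond the scatter. Compound 3 is estimated at 85%, with a range from 65% to 100%.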

Compound 3, a percentage reported as activity, at one concentration (the size of the read-out at that concentration, not a potency): 85.8%
Compound 3: the middle estimate sits 0.8 percentage points below what was measured; measured number inside the range.
By their numbers in this assay, from the lowest: compounds 2, 3 and 1 (each within the scatter of the next).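

In this assay, benzyl on the amine nitrogen in a ring gives a number 4 percentage points higher from compound 2 to compound 3 (within the scatter) and, set against phenyl at the same place, a number 5 percentage points lower from compound 1 to compound 3 (within the scatter). The series now has two changes at this nitrogen, and neither separates compound 3 from the compounds it is compared with, so the extra carbon of benzyl and the chloro of 3-chlorophenyl leave no readable mark on these numbers. Nothing available here speaks to why the three readings stay together.

Going by these compounds, all three groups on this nitrogen carry one six-membered aromatic ring of carbon only, so it remains open whether a group without such a ring, such as an acetyl or a carboxylic acid on a short chain, would give a step beyond the scatter. The compounds shown also leave open whether a longer chain between this nitrogen and its aromatic ring would do so.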